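A few compounds are considered here, and "the series" means these few. Any claim that something is new, unique, unknown or untested is made for them only; others in the source may bear on it.

In a functional assay on HL-60 cells (Homo sapiens) for inhibition, read by CCK-8 assay, with a stated time of 48 h (on this read-out lower numbers stand for stronger inhibition and higher numbers for weaker inhibition), compound 1 `O=S(=O)(c1sccc1-c1ccccc1Oc1ccc(O)c(O)c1)N1CCN(C(=S)Nc2cc(C(F)(F)F)cc(C(F)(F)F)c2)CC1` gives 2200 nM, and compound 2 `O=C(NCCNS(=O)(=O)c1ccc(-c2ccccc2Oc2ccc([N+](=O)[O-])c([N+](=O)[O-])c2)s1)Nc1cc(C(F)(F)F)cc(C(F)(F)F)c1` gives 1900 nM. These two numbers sit within the usual scatter of each other, so compound 2 cannot be set apart from compound 1 in this assay. Compound 3 `O=C(NCCNS(=O)(=O)c1ccc(-c2ccccc2Oc2ccc(O)c(O)c2)s1)Nc1cc(C(F)(F)F)cc(C(F)(F)F)c1` is not yet measured. It differs from compound 2 in one place: 3,4-dihydroxyphenyl in place of 3,4-dinitrophenyl on an oxygen on an aromatic ring. For the measured compounds named here, no comparable step between measured compounds exists, so no shift beyond the scatter is expected in this assay, and the step of a 1.1-fold higher number from compound 2 to compound 3 (0.02 log units; within the scatter) reflects that expectation. Compound 3 is estimated at 2000 nM, between 700 nM and 6000 nM.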

Compound 3, half-maximal inhibitory concentration: 10500 nM
Compound 3: the middle estimate sits 5.3-fold (0.72 log units) below what was measured; measured number outside the range, above it.
By their numbers in this assay, from the lowest: compounds 2 and 1 (each within the scatter of the next); then compound 3.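

At this place, on an oxygen on an aromatic ring, the choice of group changes the result: in this assay, 3,4-dihydroxyphenyl in place of 3,4-dinitrophenyl gives a 5.5-fold higher number from compound 2 to compound 3 (0.74 log units; beyond the scatter). For the compounds shown here, this is the first comparison here of compounds that differ in one place, and the 3,4-dinitrophenyl group goes with the stronger inhibition. No measurement shown explains this shift. Going by these compounds, how an unsubstituted phenyl or a methoxyphenyl would compare at this place remains open. So does whether the same step would hold on the core of compound 1.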